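Shrinking the Saturated Ring on a Shared Core

The source may report more compounds than this note shows. Statements on the series, on what has been measured and on what is new or still open speak of the compounds shown alone.

Three compounds have been measured so far:

Compound 1, `Nc1cccc(CNc2cc(C(F)(F)F)cc3[nH]ncc23)c1`, gives 55% in an assay for inhibition of Indoleamine 2,3-dioxygenase 1 (Homo sapiens), with stated times of 10 min and 60 min, tested at 100 uM; on this read-out lower numbers stand for a weaker effect and higher numbers for a stronger effect at the one concentration tested.
Compound 2, `Oc1ccc(CNc2cc(C(F)(F)F)cc3[nH]ncc23)cc1`, gives 81% in this assay.
Compound 3, `FC(F)(F)c1cc(NC[C@H]2CCCCN2)c2cn[nH]c2c1`, gives 69% in this assay.

All three share the same core and differ only in the group on a saturated chain carbon bound to a nitrogen on an aromatic ring. Compound 3 stands second of the three numbers: it lies a number 14 percentage points higher from compound 1 to compound 3 (beyond the scatter), and a number 12 percentage points lower from compound 2 to compound 3 (beyond the scatter). Both steps are modest.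

Compound 4, `FC(F)(F)c1cc(NC[C@H]2CCCN2)c2cn[nH]c2c1`, has not yet been measured. Its difference from compound 3 is pyrrolidin-2-yl in place of piperidin-2-yl on a saturated chain carbon bound to a nitrogen on an aromatic ring. Within the data shown here, no measured step swaps one saturated ring for a smaller one; the two steps that touch this position exchange a whole aromatic group for another group and each shifted the number only moderately. The change here keeps the same kind of group and is smaller, so any shift in this assay is expected to stay within the usual scatter, with no clear direction. Compound 4 is therefore expected to give 65%, in a range from 45% to 85%, meaning an expected step of a number 4 percentage points lower from compound 3 to compound 4 (within the scatter).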

Compound 4, a percentage reported as inhibition, at one concentration (the size of the read-out at that concentration, not a potency): 83%
Estimate against measurement, compound 4: 18 percentage points below; low and high end bracket the measured number.
By their numbers in this assay, from the lowest: compound 1; then compound 3; then compounds 2 and 4 (each within the scatter of the next).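

Exchanging piperidin-2-yl for pyrrolidin-2-yl gives a number 14 percentage points higher from compound 3 to compound 4 (beyond the scatter) in this assay, so at this position even the small change from a six-membered to a five-membered saturated ring can move the read-out beyond the usual scatter. The pyrrolidin-2-yl group also puts a saturated ring level with an aromatic group, with a number 2 percentage points higher from compound 2 to compound 4 (within the scatter) for its exchange with 4-hydroxyphenyl, while its exchange with 3-aminophenyl gives a number 28 percentage points higher from compound 1 to compound 4 (beyond the scatter), so among these compounds an aromatic ring is not required to reach the level of compound 2. Nothing available here accounts for the gap between the two saturated rings.

Still open, as far as these compounds go, is whether the trend continues to a smaller ring such as azetidin-2-yl, and what happens with an open chain such as a 2-aminoethyl group, a methyl group on the ring nitrogen, or the opposite stereocentre. Each number also comes from a single concentration, so these compounds give the size of the effect at that concentration and leave their potencies unknown.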